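Adding a hydroxy group to compound 3

The source may report more compounds than this note shows. Statements on the series, on what has been measured and on what is new or still open speak of the compounds shown alone.

compound 1 `CC(C)CCn1cnc2c(NCc3cccc(Cl)c3)nc(N[C@H]3CC[C@H](N)CC3)nc21`: 3100 nM
compound 2 `CC(C)CCn1cnc2c(Nc3cccc(Cl)c3)nc(N[C@H]3CC[C@H](N)CC3)nc21`: 1500 nM
compound 3 `CC(C)CCn1cnc2c(Nc3ccccc3)nc(N[C@H]3CC[C@H](N)CC3)nc21`: 3500 nM

These numbers come from a functional assay on K562 cells (Homo sapiens) for inhibition, read by fluorescence, with a stated time of 72 h; a lower number here means a stronger inhibitor of growth, a higher number a weaker inhibitor of growth. Compound 3 cannot be told apart from its closest neighbour on these numbers, a 1.1-fold higher number from compound 1 to compound 3 (0.05 log units; within the scatter). Its one clear gap is a 2.3-fold higher number from compound 2 to compound 3 (0.37 log units; beyond the scatter).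

Compound 4 `CC(C)CCn1cnc2c(Nc3cccc(O)c3)nc(N[C@H]3CC[C@H](N)CC3)nc21` carries a single change from compound 3: hydroxy in place of hydrogen on an aromatic carbon. This is hydroxy in place of hydrogen on an aromatic carbon, meta to a large group. The nearest measured guide is the modest step of a 2.3-fold higher number from compound 2 to compound 3 (0.37 log units; beyond the scatter), where hydrogen replaces chloro. Among the compounds with values here, no measured compound carries a hydroxy group, so that guide is loose. A small move toward a lower number in this assay is expected, and the expected step is a 1.8-fold lower number from compound 3 to compound 4 (0.24 log units; within the scatter). Compound 4 is estimated at 2000 nM, with an expected range of 700 nM to 5500 nM.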

Compound 4, concentration for 50% growth inhibition: 7600 nM
Estimate against measurement, compound 4: 3.8-fold (0.58 log units) below; measured number outside the range, above it.
By their numbers in this assay, from the lowest: compound 2; then compounds 1 and 3 (each within the scatter of the next); then compound 4.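

In this assay, the same aromatic carbon now shows change in both directions: chloro gave a lower number than hydrogen, while hydroxy gives a higher one (a 2.2-fold higher number from compound 3 to compound 4 (0.34 log units; beyond the scatter)). The two substituents are separated by the widest step in the set (a 5.1-fold higher number from compound 2 to compound 4 (0.70 log units; beyond the scatter)), so the choice of group here clearly matters. Compound 4 also sits apart from the 3-chlorobenzyl compound (a 2.5-fold higher number from compound 1 to compound 4 (0.39 log units; beyond the scatter)). Nothing available explains why hydroxy and chloro pull in opposite directions. As far as these compounds go, whether a methoxy or fluoro group on this carbon would behave more like hydroxy or chloro remains open.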